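The compounds below may be only part of what the source reports. "The series", "measured", "known", "first", "only" and "open" are said of these compounds alone.

Compound 1 `O=C(Nc1cc(-c2ccccn2)n[nH]1)N1CCC(Oc2ccccc2)CC1` gives > 40000 nM in an ADME assay on cells (Peritoneal macrophage cell, Mus musculus) for cytotoxicity, read by fluorescence and resazurin assay, with a stated time of 3 days (on this read-out lower numbers stand for higher toxicity in this test and higher numbers for lower toxicity in this test), which is a limit of the assay and not a number.
Compound 2 `O=C(Nc1cc(-c2ccccn2)n[nH]1)c1ccc(Cl)cc1` gives > 64000 nM in this assay, again only a limit of the assay.
Compound 3 `COc1ccc(C(=O)Nc2[nH]nc(-c3ccccn3)c2C2CC2)cc1` gives > 64000 nM in this assay, also a limit of the assay.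

Where compound 1 stands is therefore known only as a bound: its value sits at the limit of > 40000 nM in this assay, at which 1 of the 3 values shown sits, while the two other compounds sit at the limit of > 64000 nM in this assay, at which 2 of the 3 values shown sit. No two of these compounds differ in a single place, so no measured step connects them, and of each pair the data say only what two limits show.

Compound 4 `O=C(Nc1cc(-c2ccccn2)n[nH]1)N1CCC(c2cccc(F)c2)CC1` is not yet measured. It differs from compound 1 by 3-fluorophenyl in place of phenoxy on a saturated ring carbon. Within the data shown here, with compound 1 known only as a limit, no measured step gives a size to expect for this change in this assay, and no step beyond the scatter is expected in either direction, the most likely outcome being that compound 4 again reaches only a limit. Compound 4 is estimated at 60000 nM, within 20000 nM to 200000 nM. This estimate is expected to amount to a step that the limit leaves unreadable from compound 1 to compound 4, staying inside the scatter.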

Compound 4, half-maximal cytotoxic concentration: > 45000 nM
Compound 4: a limit, no number; the forecaster's own chance of this, stated with the estimate: 85%; the middle value does not contradict the limit.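

In this assay compound 4 gives > 45000 nM, which is a limit of the assay. Compound 1 is likewise known only as a limit, and the step between compound 1 and compound 4 cannot be read. The compounds shown leave open where any half-maximal cytotoxic concentration lies, and whether 3-fluorophenyl in place of phenoxy shifts it at all.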